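The source may report more compounds than this note shows. Statements on the series, on what has been measured and on what is new or still open speak of the compounds shown alone.

Measured so far:

compound 1 `Cc1ccc(Nc2ccc3nc(N)nc(N)c3n2)cc1` — 2630 nM
compound 2 `CCCN(c1ccccc1)c1ccc2nc(N)nc(N)c2n1` — 1340 nM
compound 3 `CC(C)N(c1ccccc1)c1ccc2nc(N)nc(N)c2n1` — 1370 nM

In an ADME assay on isolated protein for inhibition of Dihydrofolate reductase (Homo sapiens), using NADPH (on this read-out higher numbers stand for weaker inhibition and lower numbers for stronger inhibition), compound 3 gives 1370 nM, the second highest of the three numbers. Its nearest neighbour is compound 2: the step of a 1.0-fold higher number from compound 2 to compound 3 (0.01 log units; within the scatter) lies within the scatter, so the two cannot be told apart. Going by the values given here, the furthest value is that of compound 1, which in this assay gives 2630 nM; that gap is also within the scatter, and no single-point step connects compound 1 to the other two.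

Compound 4 `CCN(c1ccccc1)c1ccc2nc(N)nc(N)c2n1` is not yet measured. It differs from compound 3 by hydrogen in place of methyl on a saturated chain carbon bound to a nitrogen on an aromatic ring and a saturated chain carbon. Among the compounds with values here, the only measured step that bears on a change of this kind is a 1.0-fold higher number from compound 2 to compound 3 (0.01 log units; within the scatter), a swap of one small alkyl group on the ring nitrogen for another, and it produced no movement beyond the scatter. On that basis the step of a 1.0-fold higher number from compound 3 to compound 4 (0.01 log units; within the scatter) is expected to be within the scatter as well, with no direction to call. Compound 4 is therefore estimated at 1400 nM, with a range from 700 nM to 2800 nM.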

Compound 4, half-maximal inhibitory concentration: 1570 nM
Compound 4: the middle estimate sits 1.1-fold (0.05 log units) below what was measured; low and high end bracket the measured number.
By their numbers in this assay, from the lowest: compounds 2, 3, 4 and 1 (each within the scatter of the next).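

In this assay, going from isopropyl to ethyl, on a saturated chain carbon bound to a nitrogen on an aromatic ring and a saturated chain carbon, gives a 1.1-fold higher number from compound 3 to compound 4 (0.06 log units; within the scatter). The second change now available, hydrogen in place of methyl on a saturated chain carbon, two bonds along the chain from a nitrogen on an aromatic ring, gives a 1.2-fold higher number from compound 2 to compound 4 (0.07 log units; within the scatter), so propyl, isopropyl and ethyl on that nitrogen cannot be told apart, whether the chain is branched or not. No supporting data bear on why this position tolerates these changes.

Still open, on these data alone, is whether a longer chain such as hexyl, or a chain ending in an amine, on that nitrogen stays within the scatter of these values. Also open, as far as these compounds go, is what a carboxylic acid would do on the aromatic ring carried by that nitrogen, which is the same in compound 2, compound 3 and compound 4.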